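Shortening the chain on the carbonyl of compound 1

This account rests on a few compounds, and the source may have more. Where it says the series, first, only, none or still open, it means among the compounds named here.

In an ADME assay on the whole organism for metabolic stability, with Rattus norvegicus as the target, at a dose of 10 mg/kg by the intraperitoneal route (on this read-out higher numbers stand for a longer-lived compound and lower numbers for a shorter-lived compound), compound 1 `Cc1c(OCCCCOc2ccc(F)c(C(=O)O)c2)ccc(C(=O)CC(C)(C)C)c1O` gives 1.33 h. That lies within the scatter of compound 2 `Cc1c(OCCCCOc2ccc(C(=O)CC(C)(C)C)c(O)c2C)cccc1C(=O)O` at 1.77 h. Compound 3 `COc1ccc(C(=O)O)cc1OCCCCOc1ccc(C(=O)CC(C)C)c(O)c1C` gives 0.333 h, and its gap to compound 1 is larger than the scatter, with compound 3 the shorter-lived of the two. Compound 4 `Cc1c(OCCCCOc2ccc(F)c(C(=O)O)c2)ccc(C(=O)C(C)C)c1O` keeps the core of compound 1 and swaps one group: isopropyl in place of neopentyl on a carbonyl carbon. Among the measured compounds shown here, the only measured step, a 1.3-fold higher number from compound 1 to compound 2 (0.12 log units; within the scatter), lies elsewhere on the molecule and says nothing direct about this swap. Compound 1 differs from compound 3 on that carbonyl and elsewhere too, so compound 3 at 0.333 h offers only a weak hint of a shorter half-life. A modest fall is expected, estimated as a 1.7-fold lower number from compound 1 to compound 4 (0.22 log units; within the scatter). For compound 4 the expected value is 0.8 h, within a range of 0.35 h to 1.7 h.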

Compound 4, half-life: 0.5 h
Beside the measured number, compound 4's estimate is 1.6-fold (0.20 log units) above it, and the stated range covers the measured number.
By their numbers in this assay, from the lowest: compounds 3 and 4 (each within the scatter of the next); then compounds 1 and 2 (each within the scatter of the next).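

Swapping neopentyl for isopropyl on a carbonyl carbon in this assay gives a 2.7-fold lower number from compound 1 to compound 4 (0.42 log units; beyond the scatter) and is the only single change shown at this position. The one earlier step, made elsewhere on the molecule, stayed within the scatter, so this is the first single change shown to shift half-life beyond it. Nothing measured here explains the drop.

Still open, from the compounds shown here alone, is how half-life would respond to a methyl, an ethyl, a cyclopropyl ring or a longer chain on that carbonyl. Going by these compounds, whether this swap would have a similar effect in compound 2 also remains unknown.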